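The source may report more compounds than this note shows. Statements on the series, on what has been measured and on what is new or still open speak of the compounds shown alone.

Compound 2, `CC[C@H](NC(C)=O)c1cc(Cl)ccc1C1CCN(C(=O)[C@@H]2CN(C(C)(C)C)C[C@H]2c2ccc(Cl)cc2Cl)CC1`, gives 156 nM in a functional assay on CHO cells for agonist activity at Melanocortin receptor 4 (Homo sapiens), read by cAMP accumulation (on this read-out higher numbers stand for an effect only at larger amounts of compound and lower numbers for an effect already at smaller amounts), which is the higher of the two numbers recorded here. Among the measured compounds shown here, the only other measured compound is compound 1, `CC[C@H](NC(C)=O)c1cc(Cl)ccc1C1CCN(C(=O)[C@@H]2CN(C(C)(C)C)C[C@H]2c2ccc(F)cc2F)CC1`, which in this assay gives 17.9 nM. The step between them, an 8.7-fold higher number from compound 1 to compound 2 (0.94 log units; beyond the scatter), came with 2,4-dichlorophenyl in place of 2,4-difluorophenyl on a saturated ring carbon, so both halogens changed together.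

Compound 3, `CC[C@H](NC(C)=O)c1cc(Cl)ccc1C1CCN(C(=O)[C@@H]2CN(C(C)(C)C)C[C@H]2c2ccc(F)cc2Cl)CC1`, has not yet been measured in this assay. It differs from compound 2 in one place: fluoro in place of chloro on an aromatic carbon. Cut one bond further out, the same change reads 2,4-dichlorophenyl to 2-chloro-4-fluorophenyl, so compound 3 sits halfway between the aryl groups of compound 1 and compound 2. For the measured compounds named here, the only step that bears on it is the one between those two compounds, an 8.7-fold higher number from compound 1 to compound 2 (0.94 log units; beyond the scatter), which covered two chloro-for-fluoro exchanges at once; reversing one of them is expected to recover part of that step, in the direction of a lower number. Compound 3 is therefore estimated at 55 nM, within 22 nM to 140 nM, a step of a 2.8-fold lower number from compound 2 to compound 3 (0.45 log units; beyond the scatter) expected.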

Compound 3, half-maximal effective concentration: 215 nM
For compound 3 the middle estimate is 3.9-fold (0.59 log units) below the measured one; the whole stated range lies below it.
By their numbers in this assay, from the lowest: compound 1; then compounds 2 and 3 (each within the scatter of the next).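

At the carbon para to a large group, chloro and fluoro could not be told apart in this assay: with this exchange alone, the result is a 1.4-fold higher number from compound 2 to compound 3 (0.14 log units; within the scatter). The separation from compound 1 appears instead with a single exchange on the aryl ring, from 2,4-difluorophenyl to 2-chloro-4-fluorophenyl, which gives a 12-fold higher number from compound 1 to compound 3 (1.08 log units; beyond the scatter), so among these three compounds the lower number is seen only with 2,4-difluorophenyl, and the halogen at the carbon para to a large group does not account for the earlier step on its own. No measured property or other evidence shown here accounts for this difference between the two exchanges.

As far as these compounds go, it remains open whether the 4-chloro-2-fluorophenyl group, the one mixed arrangement absent from this set, would stay close to compound 1 or to compound 3. From the compounds shown here alone, it is also open whether a hydrogen, a methyl, a methoxy or a nitrile at the carbon para to a large group would keep the number where these two halogens leave it.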